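This account rests on a few compounds, and the source may have more. Where it says the series, first, only, none or still open, it means among the compounds named here.

Compound 1, `COc1ccc(/C=C/C(=O)OCC(=O)Nc2ccccc2)cc1OC`: > 200000 nM
Compound 2, `CCOc1ccc(COc2c(OC)cc(/C=C/C(=O)OCC(=O)Nc3ccccc3)cc2OC)cc1`: > 200000 nM
Compound 3, `O=C(COC(=O)/C=C/c1ccc(O)c(O)c1)Nc1ccc(Cl)cc1`: 99400 nM

Of the compounds shown here, three have been tested in a functional assay on K562 cells (Homo sapiens) for cytotoxicity, read by MTT assay, with a stated time of 72 h; on this read-out higher numbers stand for weaker inhibition and lower numbers for stronger inhibition. For compound 1 the result is a limit of the assay, > 200000 nM, and not a number. For compound 2 the result is likewise a limit, > 200000 nM. Compound 3 is the only one of the three that gives a number in this assay, 99400 nM. The other two values sit at the limit of > 200000 nM in this assay, at which 2 of the 3 values shown sit, so compound 3 stands alone as the single measured point. Within the data shown here, no two of the measured compounds differ in just one place, and no step between measured compounds can be read from them.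

Compound 4, `O=C(COC(=O)/C=C/c1ccc(O)c(O)c1)NN1CCOCC1`, is not yet measured. It differs from compound 3 in one place: morpholin-4-yl in place of 4-chlorophenyl on an amide-type nitrogen. Among the measured compounds shown here, none of the measured compounds carries a morpholin-4-yl group, so nothing shows how this assay responds to such a change. The step of a 1.5-fold higher number from compound 3 to compound 4 (0.18 log units; within the scatter) is therefore expected to be small, most likely within the usual scatter, with any movement leaning towards weaker inhibition. A limit rather than a number is also possible for compound 4, given that two of three measured results sit at the limit of > 200000 nM in this assay, at which 2 of the 3 values shown sit. Compound 4 is estimated at 150000 nM, with a range from 50000 nM to 300000 nM.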

Compound 4, half-maximal inhibitory concentration: 56800 nM
Compound 4: the middle estimate sits 2.6-fold (0.42 log units) above what was measured; measured number inside the range.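

In this assay, among these compounds, morpholin-4-yl in place of 4-chlorophenyl on an amide-type nitrogen gives a 1.8-fold lower number from compound 3 to compound 4 (0.24 log units; within the scatter), the first step that can be read, and it does not separate the two groups. At this place, a six-membered non-aromatic ring with 2 hetero atoms therefore reads the same as a chlorine-bearing six-membered aromatic ring of carbon only, so the aromatic ring and the chlorine are not needed to keep the result within the scatter of compound 3. Compound 3 and compound 4 both give a number on this read-out, while the remaining results are a limit of the assay and not numbers: the limit of > 200000 nM in this assay, at which 2 of the 4 values shown sit.

The compounds shown leave open whether a piperidin-1-yl group, which lacks the ring oxygen of morpholin-4-yl, or an open-chain dimethylamino group at this place would also stay within the scatter. They also leave open what the two hydroxyl groups shared by compound 3 and compound 4 contribute, and no other step can be read from the series.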